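The source may hold more compounds than are shown below. What is called first, only, known or untested is meant among the compounds shown, and "the series" means these compounds.

Compound 1, `COc1cc2nccc(Oc3ccc(Nc4nn(C)cc4C(=O)NCC(C)C)cc3)c2cc1C(N)=O`, gives > 10000 nM in a functional assay on BaF3 cells (Mus musculus) for antiproliferative activity, read by CCK-8 assay and cell counting, with a stated time of 76 h (on this read-out lower numbers stand for stronger inhibition and higher numbers for weaker inhibition), which is a limit of the assay rather than a number.
Compound 2, `COc1cc2nccc(Oc3ccc(Nc4nn(C)cc4C(=O)N4CCCC5CCCCC54)cc3)c2cc1C(N)=O`, gives 4330 nM in this assay.

For the measured compounds named here, compound 2 therefore holds the only number among the two results; the other result is a limit (the limit of > 10000 nM in this assay, at which 1 of the 2 values shown sits). Compound 3, `COc1cc2nccc(Oc3ccc(Nc4nn(C)cc4C(=O)Nc4ccc(F)cc4)cc3)c2cc1C(N)=O`, differs from compound 2 by a group of 8 heavy atoms (6 carbon, 1 nitrogen, 1 fluorine; one six-membered aromatic ring of carbon only) in place of a group of 10 heavy atoms (9 carbon, 1 nitrogen; one six-membered non-aromatic ring of carbon only, one six-membered non-aromatic ring with 1 hetero atom), on a carbonyl carbon. Going by the values given here, the one measured step, an at least 2.3-fold lower number from compound 1 to compound 2 (0.36 log units; beyond the scatter), also exchanged the group on the carbonyl carbon and moved the read-out beyond the scatter, so this position is sensitive to change. Compound 3 is expected to give 1500 nM, with a range from 300 nM to 8000 nM. That expectation amounts to a 2.9-fold lower number from compound 2 to compound 3 (0.46 log units; beyond the scatter).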

Compound 3, half-maximal inhibitory concentration: 3060 nM
Estimate against measurement, compound 3: 2.0-fold (0.31 log units) below; the measured number falls inside the stated range.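

In this assay the step is a 1.4-fold lower number from compound 2 to compound 3 (0.15 log units; within the scatter), so the (4-fluorophenyl)amino group, with its aromatic ring and amide hydrogen, cannot be told apart from the two-ring group it replaces. Putting 4-fluorophenyl in place of isobutyl gives an at least 3.2-fold lower number from compound 1 to compound 3 (0.51 log units; beyond the scatter), so a second ring-bearing group also gives a lower number than the open chain. Compound 1 stands at a limit, so that step has no exact size: the limit of > 10000 nM in this assay, at which 1 of the 3 values shown sits.

On these data alone, what remains open is how a piperazine ring or a carboxylic acid on this carbonyl carbon would read out, and whether any group here can move the number well beyond these two.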